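Swapping Chloro for Bromo on a Weak Inhibitor

The source may report more compounds than this note shows. Statements on the series, on what has been measured and on what is new or still open speak of the compounds shown alone.

In a functional assay on P388 cells (Mus musculus) for inhibition (on this read-out lower numbers stand for stronger inhibition and higher numbers for weaker inhibition), compound 1 (`O=C1/C(=C/c2ccc(F)cc2)Cc2ccccc21`) reads > 50000 nM as a limit of the assay and not a number. Among the compounds with values here, compound 2 (`O=C1/C(=C/c2cccc(Cl)c2)Cc2ccccc21`) gives 26300 nM as the only true number so far, which makes it the one firm reference point. Compound 3 (`O=C1/C(=C/c2cccc(Br)c2)Cc2ccccc21`) keeps the core of compound 2 and changes a single substituent, with bromo in place of chloro on an aromatic carbon. Within the data shown here, no measured pair here shows what such a swap does. The expectation is therefore modest, with no shift beyond the usual scatter in either direction, anchored on compound 2 at 26300 nM as the starting value. The estimated change is a 1.2-fold lower number from compound 2 to compound 3 (0.08 log units; within the scatter) and would stay within that scatter. The estimate for compound 3 is 22000 nM with an expected range from 9000 nM to 50000 nM in this test.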

Compound 3, half-maximal inhibitory concentration: 21000 nM
For compound 3 the middle estimate is 1.0-fold (0.02 log units) above the measured one; measured number inside the range.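

Putting bromo in place of chloro on an aromatic carbon gives, in this assay, a 1.3-fold lower number from compound 2 to compound 3 (0.10 log units; within the scatter). Within the data shown here, this is the first measured swap, and it shows that at this place, meta to a large group, the two halogens cannot be told apart on this read-out. Compound 3 also gives a second true number alongside compound 2, so this pair can be compared directly.

Still open is whether any other group at this place, such as an amine or a carboxylic acid, would move the number beyond the scatter, since the swap shown exchanges only one halogen for another. A change towards weaker inhibition might not give a true number at all, since the assay has an upper limit close to these values: the limit of > 50000 nM in this assay, at which 1 of the 3 values shown sits.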